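A few compounds are considered here, and "the series" means these few. Any claim that something is new, unique, unknown or untested is made for them only; others in the source may bear on it.

Compound 1 `Clc1ccc(C(/C=C/c2ccccc2)=N\Nc2nncc3ccccc23)cc1`: 5.4 nM
Compound 2 `Cc1cc(NS(=O)(=O)c2ccc(Nc3nncc4ccccc34)cc2)no1`: 54 nM

In a functional assay on OVCAR-3 cells (Homo sapiens) for antiproliferative activity, read by sulforhodamine B assay, with a stated time of 72 h (on this read-out higher numbers stand for weaker inhibition and lower numbers for stronger inhibition), compound 1 gives 5.4 nM, the lowest of the two numbers shown. Compound 2 gives 54 nM, a gap beyond the scatter. Compound 3 `C(=C/c1ccccc1)\C(=N\Nc1nncc2ccccc12)c1ccccc1` has not been measured. It differs from compound 1 by hydrogen in place of chloro on an aromatic carbon. Among the measured compounds shown here, no measured pair shows this change, so the step in this assay is expected to be small, toward weaker inhibition, near the edge of the scatter. Compound 3 is therefore expected to give about 12 nM, within 4 nM to 40 nM. The step this estimate means, a 2.2-fold higher number from compound 1 to compound 3 (0.35 log units; beyond the scatter), is expected to stay modest.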

Compound 3, half-maximal inhibitory concentration: 3.3 nM
Compound 3: the middle estimate sits 3.6-fold (0.56 log units) above what was measured; measured number below the stated range.
By their numbers in this assay, from the lowest: compounds 3 and 1 (each within the scatter of the next); then compound 2.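

In this assay, going from 4-chlorophenyl to phenyl gives a 1.6-fold lower number from compound 1 to compound 3 (0.21 log units; within the scatter) and so the chloro is not needed for the low numbers seen here. On this read-out, the two compounds cannot be told apart, which means that a hydrogen serves as well as chloro at this position. The data at hand offer no explanation for this result. Still open, from the compounds shown here alone, is whether an amine, a methoxy group or a carboxylic acid on this same carbon would also keep the number this low. Going by these compounds, whether larger groups there would do so also remains unknown.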